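Swapping Cyclobutyl for Cyclopentyl in a Fast-Cleared Compound

The compounds below may be only part of what the source reports. "The series", "measured", "known", "first", "only" and "open" are said of these compounds alone.

- Compound 1 `c1ccc(COc2ccc3c(c2)CCN(C2CCC2)CC3)cc1` gives > 50 mL.min-1.g-1 in an ADME assay (liver) for metabolic stability, with Liver microsome (Rattus norvegicus) as the target, using microsomes; on this read-out higher numbers stand for fast clearance and lower numbers for slow clearance (a limit, not a number)
- Compound 2 `c1cc2c(cc1OCC1CCNCC1)CCN(C1CCC1)CC2` gives 0.7 mL.min-1.g-1 in this assay (a measured number)

Compound 1 stands at a limit of the read-out rather than at a number (the limit of > 50 mL.min-1.g-1 in this assay, at which 1 of the 2 values shown sits). Compound 3 `c1ccc(COc2ccc3c(c2)CCN(C2CCCC2)CC3)cc1` keeps the rest of compound 1 but carries cyclopentyl in place of cyclobutyl on an amine nitrogen in a ring. Among the measured compounds shown here, the one measured step, an at least 71-fold lower number from compound 1 to compound 2 (1.85 log units; beyond the scatter), is large and beyond the scatter, yet it concerns a different place in the molecule and leaves the cyclobutyl untouched. No measurement tests the ring swap directly. Compound 3 keeps the phenyl whose replacement gave the large step (an at least 71-fold lower number from compound 1 to compound 2 (1.85 log units; beyond the scatter)), so a comparably large fall is not expected in this assay. Clearance should stay fast, and the assay may again report only a limit. The expected change, a step that the limit leaves unreadable from compound 1 to compound 3, is no step beyond the scatter. Compound 3 is estimated at 60 mL.min-1.g-1, with an expected range from 30 mL.min-1.g-1 to 120 mL.min-1.g-1 as the likely span.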

Compound 3, intrinsic clearance in microsomes: > 50 mL.min-1.g-1
Compound 3: a limit, no number (the forecaster's own chance of this, stated with the estimate: 70%); the middle value does not contradict the limit.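

In this assay compound 3 gives > 50 mL.min-1.g-1, which is a limit and not a number. Compound 1 also stands at a limit, so no step can be read from compound 1 to compound 3: the limit of > 50 mL.min-1.g-1 in this assay, at which 2 of the 3 values shown sit. The compounds shown leave open whether cyclopentyl in place of cyclobutyl changes clearance at all, and by how much.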